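The source may hold more compounds than are shown below. What is called first, only, known or untested is meant among the compounds shown, and "the series" means these compounds.

In a functional assay on MDA-MB-231 cells (Homo sapiens) for antiproliferative activity, read by sulforhodamine B assay, with a stated time of 48 h (on this read-out higher numbers stand for weaker inhibition and lower numbers for stronger inhibition), compound 1 (`COc1cc(OC)c2sc(-c3ccc(N/C=C\C(=O)c4cc(OC)c(OC)c(OC)c4Br)c(C)c3)nc2c1`) gives 17300 nM, which puts it at the upper end of the three measured numbers. Compound 2 (`COc1cc(OC)c2sc(-c3ccc(N/C=C\C(=O)c4cc(OC)c(OC)c(OC)c4)c(C)c3)nc2c1`), with hydrogen in place of bromo on an aromatic carbon, gives 13800 nM, a 1.3-fold lower number from compound 1 to compound 2 (0.10 log units; within the scatter). Compound 3 (`COc1cc(C(=O)/C=C\Nc2ccc(-c3nc4cc(OC)c(OC)c(OC)c4s3)cc2C)c(Br)c(OC)c1OC`), with methoxy in place of hydrogen on an aromatic carbon, gives 7300 nM, a 2.4-fold lower number from compound 1 to compound 3 (0.37 log units; beyond the scatter).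

Compound 4 (`COc1cc(OC)c2sc(-c3ccc(N/C=C\C(=O)c4cc(OC)c(OC)c(OC)c4Br)cc3)nc2c1`) has not been measured yet. It differs from compound 1 by hydrogen in place of methyl on an aromatic carbon, ortho to a large group and meta to a large group (hydrogen in place of methyl on an aromatic carbon). For the measured compounds named here, no measured pair shows this exchange, so the two steps above are only indirect guides. Both are single changes elsewhere on the molecule, and neither is large. A step beyond the scatter is therefore not expected, and the direction remains uncertain. The expected change is a 1.2-fold lower number from compound 1 to compound 4 (0.09 log units; within the scatter), a small estimated shift. For compound 4, the estimated value is 14000 nM, with an expected range from 6500 nM to 30000 nM.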

Compound 4, half-maximal inhibitory concentration: 16100 nM
The estimate for compound 4 lay 1.2-fold (0.06 log units) below the measured number; measured number inside the range.
By their numbers in this assay, from the lowest: compounds 3, 2, 4 and 1 (each within the scatter of the next, the first and the last beyond it).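

In this assay this aromatic carbon, ortho to a large group and meta to a large group, is now read directly: hydrogen in place of methyl gives a 1.1-fold lower number from compound 1 to compound 4 (0.03 log units; within the scatter), so in this compound the methyl can be removed without a change beyond the usual scatter. The earlier steps shown here concerned other places on the molecule and could not show this, and the present reading rests on a single pair, with compound 1 as its starting point. No measurement offered here accounts for this small step.

From the compounds shown here alone, whether the same exchange reads alike starting from compound 2 or compound 3 stays open. Also open is what an amine, a carboxylic acid or an ethyl group would do at this carbon: methyl and hydrogen are the only groups shown there.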